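The compounds below may be only part of what the source reports. "The series", "measured", "known", "first", "only" and "open" are said of these compounds alone.

Measured so far:
compound 1, `O=C(/C=C/c1cccc(OCc2ccccc2)c1)c1ccccc1Br`: 2500 nM
compound 2, `O=C(/C=C/c1cccc(OCc2ccccc2)c1)c1ccc(Br)cc1`: 1800 nM
compound 3, `COc1ccc(C(=O)/C=C/c2cccc(OCc3ccccc3)c2)cc1`: 38100 nM

In a functional assay on A2780 cells (Homo sapiens) for cytotoxicity, read by MTT assay, with a stated time of 68 h (on this read-out higher numbers stand for weaker inhibition and lower numbers for stronger inhibition), compound 3 stands at the highest of the three numbers; its nearest neighbour is compound 1, shown by a 15-fold higher number from compound 1 to compound 3 (1.18 log units; beyond the scatter), and the furthest is compound 2, shown by a 21-fold higher number from compound 2 to compound 3 (1.33 log units; beyond the scatter). Compound 4, `O=C(/C=C/c1cccc(OCc2ccccc2)c1)c1cccc(Br)c1`, has not yet been measured. It differs from compound 3 in one place: 3-bromophenyl in place of 4-methoxyphenyl on a carbonyl carbon.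

Within the data shown here, two measured steps bear on this change. Both a 15-fold higher number from compound 1 to compound 3 (1.18 log units; beyond the scatter) and a 21-fold higher number from compound 2 to compound 3 (1.33 log units; beyond the scatter) show that moving from a bromophenyl to the 4-methoxyphenyl raised the number by a large amount, well beyond the scatter. The reverse move, back to a bromophenyl, is therefore expected to lower the number by a comparable amount. Within the bromophenyl compounds, a 1.4-fold lower number from compound 1 to compound 2 (0.14 log units; within the scatter) lies within the scatter, so the two bromo placements already measured look alike. Compound 4 is thus expected to come out near compound 1 and compound 2, estimated at 2100 nM with a range of 900 nM to 5000 nM. This estimate means a step of an 18-fold lower number from compound 3 to compound 4 (1.26 log units; beyond the scatter), expected to be large and downward.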

Compound 4, half-maximal inhibitory concentration: 6300 nM
Compound 4: the middle estimate sits 3.0-fold (0.48 log units) below what was measured; measured number above the stated range.
By their numbers in this assay, from the lowest: compounds 2 and 1 (each within the scatter of the next); then compound 4; then compound 3.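

In this assay, putting 3-bromophenyl in place of 4-methoxyphenyl lowers the number only part of the way towards the other bromophenyl compounds (a 6.0-fold lower number from compound 3 to compound 4 (0.78 log units; beyond the scatter)), so a bromophenyl on this carbonyl carbon does not in itself restore their level. Where the bromo group sits on the ring therefore does matter, which the two earlier bromo compounds alone did not reveal: the 3-bromophenyl stands apart both from the 4-bromophenyl (a 3.5-fold higher number from compound 2 to compound 4 (0.54 log units; beyond the scatter)) and from the 2-bromophenyl (a 2.5-fold higher number from compound 1 to compound 4 (0.40 log units; beyond the scatter)). Nothing available accounts for this difference between the bromo placements.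

The compounds shown leave open whether a 3-methoxyphenyl would lie closer to compound 3 or to compound 4. They also leave open how a chlorophenyl or an aminophenyl would fare on this carbonyl carbon.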